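The source may report more compounds than this note shows. Statements on the series, on what has been measured and on what is new or still open speak of the compounds shown alone.

Of the compounds shown here, three sharing one core have so far been tested in an assay on isolated protein for inhibition of hexokinase-3 (Rattus norvegicus), with a stated time of 6 h, tested at 10 mM; on this read-out higher numbers stand for more inhibition at the one concentration tested (going by the name of the read-out) and lower numbers for less inhibition. Compound 1 `O=C(CI)NCCCCCC(=O)NCCCCCCNc1ncnc2c1ncn2[C@@H]1O[C@H](COP(=O)(O)OP(=O)(O)OP(=O)(O)O)[C@@H](O)[C@H]1O` gives 0% in this assay. Compound 2 `Nc1ncnc2c1nc(NCCCCCCCCNC(=O)CI)n2[C@@H]1O[C@H](COP(=O)(O)OP(=O)(O)OP(=O)(O)O)[C@@H](O)[C@H]1O`, a close relative carrying the same reactive end group on a differently placed chain, gives 0%. Another relative with the same end group is compound 3 `O=C(CI)NCCCCCC(=O)NCCCCNc1ncnc2c1ncn2[C@@H]1O[C@H](COP(=O)(O)OP(=O)(O)OP(=O)(O)O)[C@@H](O)[C@H]1O`, and in this assay compound 3 gives 0%. Compound 1 therefore stands level with compounds 2 and 3 at the digits shown: none of the three produces measurable inhibition at the single concentration tested, and no compound among them can be called stronger or weaker than another.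

Compound 4 `O=C(CI)NCCCC(=O)NCCCCCCNc1ncnc2c1ncn2[C@@H]1O[C@H](COP(=O)(O)OP(=O)(O)OP(=O)(O)O)[C@@H](O)[C@H]1O` has not yet been measured. It differs from compound 1 in a single place: ((iodomethyl)carbonyl)amino in place of 2-(((iodomethyl)carbonyl)amino)ethyl on a saturated chain carbon, three bonds along the chain from a carbonyl carbon. The reactive end group and the shared core are the same in both compounds; only the saturated chain is altered.

Since compound 1 sits at 0% and compounds 2 and 3 sit at the same level despite their own chain differences, nothing in the data suggests that this change would move the read-out. The expected step of no change at the digits printed from compound 1 to compound 4 (within the scatter) is therefore none beyond the usual scatter. Compound 4 is expected to give about 0% in this assay, with a likely range from 0% to 10%.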

Compound 4, a percentage reported as inhibition, at one concentration (the size of the read-out at that concentration, not a potency): 0%
The estimate for compound 4 equals the measured number at the digits printed; low and high end bracket the measured number.
By their numbers in this assay, from the lowest: compounds 1, 2, 3 and 4 (each within the scatter of the next).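

In this assay, going by these compounds alone, the step of no change at the digits printed from compound 1 to compound 4 (within the scatter) is the first that can be read between two compounds differing in one place, and it isolates the saturated chain, with the shared core and the reactive end group left as they are. Putting ((iodomethyl)carbonyl)amino, with 5 heavy atoms, in place of 2-(((iodomethyl)carbonyl)amino)ethyl, with 7, brings no inhibition into view at this position, three bonds along the chain from a carbonyl carbon. Both compounds sit at the bottom of the read-out, so this step can show no loss of inhibition and shows only that this edit produces no gain at the one concentration tested, and no measurement at hand offers an explanation for this result.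

The compounds shown leave open whether any other group at this position could give measurable inhibition, such as an amine, a carboxylic acid or a longer chain like 5-(((iodomethyl)carbonyl)amino)pentyl. With every reading at the same level, they also leave open whether this position matters for inhibition at all.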